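Swapping the Bromophenyl Amide for a Thiophene Ring

This account rests on a few compounds, and the source may have more. Where it says the series, first, only, none or still open, it means among the compounds named here.

Measured compounds:
Compound 1, `O=C(NCCCCCCCl)Nc1c(C(O)(C(F)(F)F)C(F)(F)F)ccc2ccccc12`: 4840 nM
Compound 2, `O=C(Nc1c(C(O)(C(F)(F)F)C(F)(F)F)ccc2ccccc12)c1ccccc1Cl`: 2040 nM
Compound 3, `O=C(Nc1c(C(O)(C(F)(F)F)C(F)(F)F)ccc2ccccc12)c1ccc(Br)cc1`: 47 nM

The three compounds share one core and differ only in the group on the carbonyl carbon. In an assay on LtK cells with ATP-sensitive inward rectifier potassium channel 11 (Homo sapiens) as the target (a higher number here means that more compound is needed for the effect, a lower number that less compound is needed), compound 3 gives the lowest number of the three: compound 2 lies a 43-fold lower number from compound 2 to compound 3 (1.64 log units; beyond the scatter) and compound 1 lies a 100-fold lower number from compound 1 to compound 3 (2.01 log units; beyond the scatter). Compound 4, `O=C(Nc1c(C(O)(C(F)(F)F)C(F)(F)F)ccc2ccccc12)c1cccs1`, has not been measured. It differs from compound 3 by thiophen-2-yl in place of 4-bromophenyl on a carbonyl carbon.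

Among the compounds with values here, no measured step matches this change. The steps that exist show that the group on the carbonyl carbon matters greatly, and that a 4-bromophenyl group gives by far the lowest number among the three. Thiophen-2-yl carries no bromine and is a smaller ring, so compound 4 is expected to give a higher number than compound 3, an increase of roughly an 8.5-fold higher number from compound 3 to compound 4 (0.93 log units; beyond the scatter), with wide uncertainty. For compound 4 the estimate in this assay is 400 nM, within a range from 80 nM to 2000 nM.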

Compound 4, half-maximal effective concentration: 12 nM
For compound 4 the middle estimate is 33-fold (1.52 log units) above the measured one, and the stated range ends above it.
By their numbers in this assay, from the lowest: compound 4; then compound 3; then compound 2; then compound 1.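

In this assay a six-membered ring carrying bromine proves unnecessary on the carbonyl carbon, since thiophen-2-yl, a five-membered aromatic ring with 1 hetero atom and no bromine, gives a 3.9-fold lower number from compound 3 to compound 4 (0.59 log units; beyond the scatter) as a modest further gain. The same ring widens the gaps to the two weakest compounds, with a 170-fold lower number from compound 2 to compound 4 (2.23 log units; beyond the scatter) and a 400-fold lower number from compound 1 to compound 4 (2.61 log units; beyond the scatter) as large steps, so the smaller ring with 5 heavy atoms now stands lowest of the four. No measurement at hand explains this change.

The compounds shown leave open whether the sulfur or the five-membered ring shape accounts for the step, which furan-2-yl or an unsubstituted phenyl on the same carbonyl carbon would help to separate. Also open, as far as these compounds go, is how a methyl or a chlorine on the thiophene ring would behave.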